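A few compounds are considered here, and "the series" means these few. Any claim that something is new, unique, unknown or untested is made for them only; others in the source may bear on it.

Measured so far in a functional assay on BT-20 cells (Homo sapiens) for antiproliferative activity, read by trypan blue exclusion; a higher number here means a weaker inhibitor, a lower number a stronger inhibitor:
- compound 1, `COc1cc(OC)c(/C=C/S(=O)(=O)Cc2ccc(C#N)cc2)c(OC)c1`: 12500 nM
- compound 2, `COc1ccc(CS(=O)(=O)/C=C/c2ccc(F)cc2)cc1`: 1500 nM
- compound 3, `COc1ccc(CS(=O)(=O)/C=C/c2ccc(Cl)cc2)cc1`: 2000 nM

Compound 3 sits second highest of the three numbers. Its nearest neighbour is compound 2, at a 1.3-fold higher number from compound 2 to compound 3 (0.12 log units; within the scatter); its furthest is compound 1, whose number is beyond the scatter from that of compound 3. Compound 1 differs from compound 3 in several places at once, so the two values show only that the gap is real, not what produces it.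

Compound 4, `COc1ccc(CS(=O)(=O)/C=C/c2ccc(N)cc2)cc1`, is the next step from compound 3: amino in place of chloro on an aromatic carbon. Among the measured compounds shown here, the one measured step that touches the same place, chloro in place of fluoro on an aromatic carbon from compound 2 to compound 3, was within the scatter. For the measured compounds named here, no measured step replaces a halogen with an amino group, so the expectation for compound 4 rests on the small movement seen around that position, widened for the untested group.

Compound 4 is therefore expected to land close to compound 3 in this assay, with a step of a 1.5-fold higher number from compound 3 to compound 4 (0.18 log units; within the scatter) that may well stay within the scatter, and an estimate of 3000 nM, spanning 800 nM to 12000 nM.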

Compound 4, half-maximal inhibitory concentration: > 20000 nM
Compound 4: only a limit was reported; the forecaster's own chance of this, stated with the estimate: 5%; middle value at least 6.6-fold (0.82 log units) away from the limit.
By their numbers in this assay, from the lowest: compounds 2 and 3 (each within the scatter of the next); then compound 1. At a limit, above all of these: compound 4.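

In this assay, compound 4 gives only a limit of the assay and not a number, and this limit is the highest position among the compounds shown: the limit of > 20000 nM in this assay, at which 1 of the 4 values shown sits.

The two halogens had suggested that this place on the ring, para to a large group, was indifferent to what it carries, with a 1.3-fold higher number from compound 2 to compound 3 (0.12 log units; within the scatter). Amino in place of either halogen does not fit that picture, with an at least 10-fold higher number from compound 3 to compound 4 (1.00 log units; beyond the scatter) and an at least 13-fold higher number from compound 2 to compound 4 (1.12 log units; beyond the scatter), both beyond the scatter. The position therefore responds strongly to the group it carries, which fluoro and chloro alone could not reveal, although a single amino compound cannot show which feature of the change matters.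

How far the loss extends remains open, as the limit gives no end point for it, and neither a hydroxyl group nor an acetamide at this place is among the compounds shown. Also open, as far as these compounds go, is whether a nitro group or a carboxylic acid here would stay with the halogens or move with the amino group.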